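The source may report more compounds than this note shows. Statements on the series, on what has been measured and on what is new or still open speak of the compounds shown alone.

Working notes on the series. Compound 1 `CCOc1ccc(-c2cccc(C(=O)NC)c2)cc1` carries a methylcarbamoyl group and an ethoxy group on the shared core. In an assay on COS-7 cells for inhibition of patatin-like phospholipase domain-containing protein 2 (Mus musculus) (on this read-out higher numbers stand for weaker inhibition and lower numbers for stronger inhibition), compound 1 gives only a limit, > 200000 nM. Compound 2 `CCOc1ccc(-c2cccc([N+](=O)[O-])c2)cc1` differs by nitro in place of methylcarbamoyl on an aromatic carbon, and the step is a step that the two limits leave unreadable from compound 1 to compound 2. In this assay compound 2 again gives only a limit, > 200000 nM. Compound 3 `CN(C)c1ccc(-c2cccc([N+](=O)[O-])c2)cc1` carries dimethylamino in place of ethoxy on an aromatic carbon, and the step is a step that the two limits leave unreadable from compound 2 to compound 3. In this assay compound 3 likewise gives only a limit, > 200000 nM. Compound 3 thus sits at the limit of > 200000 nM in this assay, at which 3 of the 3 values shown sit, together with the two other measured compounds, and neither measured step gives a readable size or direction.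

Compound 4 `CCOC(=O)Nc1cccc(-c2ccc(N(C)C)cc2)c1` differs from compound 3 by (ethoxycarbonyl)amino in place of nitro on an aromatic carbon. For the measured compounds named here, neither a step that the two limits leave unreadable from compound 1 to compound 2 nor a step that the two limits leave unreadable from compound 2 to compound 3 touches this group, and both are unreadable, so no measured step bears on the change; the (ethoxycarbonyl)amino group is new to the series and the estimate rests on the limit alone. Compound 4 is expected to give about 5000 nM in this assay, within a range from 500 nM to 200000 nM. The expected step is an at least 40-fold lower number from compound 3 to compound 4 (1.60 log units; beyond the scatter).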

Compound 4, half-maximal inhibitory concentration: 3000 nM
Estimate against measurement, compound 4: 1.7-fold (0.22 log units) above; measured number inside the range.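

In this assay, for the compounds shown here, (ethoxycarbonyl)amino in place of nitro on an aromatic carbon gives an at least 66-fold lower number from compound 3 to compound 4 (1.82 log units; beyond the scatter), the first step with a readable direction, and compound 4 is the first compound with a number rather than a limit. This position therefore responds to the group it carries, at least with dimethylamino kept on the shared core; the entering group has 6 heavy atoms against 3 and 1 hydrogen-bond donor against 0, and either difference could lie behind the change. The earlier steps cannot be read, and compound 4 alone stands clear of the limit that holds the other compounds: the limit of > 200000 nM in this assay, at which 3 of the 4 values shown sit.

The compounds shown leave open which part of the (ethoxycarbonyl)amino group matters, the amide hydrogen, the carbonyl or the ethoxy end; a plain amine, an acetylamino group or a butoxycarbonylamino group at this position would separate these parts. Also open, as far as these compounds go, is whether the number holds with ethoxy in place of dimethylamino on the core of compound 4.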